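Bromo for methoxy on the acetyl-type hydroxamate series

A few compounds are considered here, and "the series" means these few. Any claim that something is new, unique, unknown or untested is made for them only; others in the source may bear on it.

Measured so far in a functional assay on K562/A02 cells (Homo sapiens) for antiproliferative activity, read by MTT assay; on this read-out lower numbers stand for stronger inhibition and higher numbers for weaker inhibition:
- compound 1 `Cc1ccc(/C(=N/NC(=S)NCCCCCC(=O)NO)c2ccccc2)cc1`: 3150 nM
- compound 2 `COc1cccc(/C(C)=N/NC(=S)NCCCCCC(=O)NO)c1`: 1890 nM

For the measured compounds named here, only these two compounds have numbers in this assay so far, and they differ in more than one place. Compound 2 gives 1890 nM and sits within the usual scatter of compound 1 at 3150 nM, so the two cannot be ranked. Going by the values given here, no measured pair differs in a single place, which leaves the data without a direct guide to any one substitution.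

The next compound is compound 3 `C/C(=N\NC(=S)NCCCCCC(=O)NO)c1cccc(Br)c1`, which goes from 3-methoxyphenyl to 3-bromophenyl. It has bromo in place of methoxy on an aromatic carbon, meta to a large group bromo in place of methoxy on an aromatic carbon and is otherwise identical to compound 2.

With nothing measured on this change, the working expectation stays anchored on compound 2 at 1890 nM, with no shift beyond the scatter in either direction. The expected change is a 1.1-fold lower number from compound 2 to compound 3 (0.05 log units; within the scatter) and is an estimate only. The estimated value for compound 3 is 1700 nM, with an expected range from 700 nM to 4000 nM.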

Compound 3, half-maximal inhibitory concentration: 520 nM
The estimate for compound 3 lay 3.3-fold (0.51 log units) above the measured number; the whole stated range lies above it.
By their numbers in this assay, from the lowest: compound 3; then compounds 2 and 1 (each within the scatter of the next).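

On an aromatic carbon meta to a large group, this assay now has its first comparison that differs in one place: bromo in place of methoxy gives a 3.6-fold lower number from compound 2 to compound 3 (0.56 log units; beyond the scatter), a step beyond the scatter. For the compounds shown here, this position is therefore not indifferent to its substituent, which the earlier compounds, differing in more than one place, could not show: the change from methoxy, with two heavy atoms and one hydrogen-bond acceptor, to bromo, with one heavy atom and no hydrogen-bond acceptor, moves the read-out towards stronger inhibition. No measurement at hand ties this step to any particular property of either group.

Going by these compounds, with only these two groups compared on this carbon, it remains open whether chloro, methyl or an amine there would give numbers closer to those of compound 3 or compound 2. Also open, on these data alone, is whether bromo in place of methoxy gives a similar step on the core of compound 1, or with a longer chain in the shared core.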